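Allyl to hydroxyethyl on the amine nitrogen

The source may hold more compounds than are shown below. What is called first, only, known or untested is meant among the compounds shown, and "the series" means these compounds.

Three compounds have numbers in a functional assay on L1210 cells (Mus musculus) for antiproliferative activity; on this read-out lower numbers stand for lower potency and higher numbers for higher potency (the scale is a negative logarithm). Compound 1 `COC(=O)c1ccc(/N=N/N(C)C)cc1` gives 3.2 and compound 3 `CN(C)/N=N/c1ccc(S(N)(=O)=O)cc1C(N)=O` gives 3.32. Compound 2 `C=CCN(C)/N=N/c1n[nH]cc1C(N)=O` stands highest of the three with 3.77; compound 3 is its nearest neighbour, a gap beyond the scatter, and compound 1 lies furthest, also beyond the scatter. Compound 4 `CN(CCO)/N=N/c1n[nH]cc1C(N)=O` is not yet measured in this assay. It differs from compound 2 by hydroxymethyl in place of vinyl on a saturated chain carbon bound to an amine nitrogen. Going by the values given here, no pair of measured compounds shows this change, so no measured precedent exists for it. In this assay a small step is expected, if anything a slight loss, within the scatter: a number 0.17 log units lower from compound 2 to compound 4 (within the scatter). Compound 4 is therefore expected to give 3.6, with a range from 3.1 to 4.1.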

Compound 4, logarithm of the reciprocal of the active concentration, log(1/C): 3.1
Estimate against measurement, compound 4: 0.50 log units above, within the range that was stated.
By their numbers in this assay, from the lowest: compounds 4, 1 and 3 (each within the scatter of the next); then compound 2.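

In this assay the change from allyl to 2-hydroxyethyl gives a number 0.67 log units lower from compound 2 to compound 4 (beyond the scatter) as the first step read at this position, so this place on the amine nitrogen is not indifferent to the change. Swapping vinyl for hydroxymethyl on the saturated chain carbon keeps the heavy-atom count yet still costs potency. No measured evidence bears on the reason for this step.

Going by these compounds alone, the single step cannot separate loss of the double bond from entry of the hydroxyl. A saturated propyl chain or a 2-methoxyethyl group on this nitrogen would tell these apart.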